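This account rests on a few compounds, and the source may have more. Where it says the series, first, only, none or still open, it means among the compounds named here.

Compound 3 `Nc1ncnc2c1c(Oc1cc(C(F)(F)F)ccn1)nn2C1CC1` carries a cyclopropyl on the aromatic nitrogen of the shared core. In an ADME assay on microsomes from liver (Mus musculus) for metabolic stability, read by LC-MS, using NADPH, with a stated time of 10 min, tested at 10 uM (a lower number here means that the compound disappears faster, a higher number that the compound lasts longer), compound 3 gives > 2.41 h, which is a limit of the assay rather than a measured number. Compound 1 `Nc1ncnc2c1c(Oc1cc(C(F)(F)F)ccn1)nn2[C@H]1CC[C@@H](N)CC1` gives 0.917 h in this assay, and compound 2 `Nc1ncnc2c1c(Oc1cc(C(F)(F)F)ccn1)nn2C1CCC1` gives 0.128 h. The steps onto the cyclopropyl were an at least 2.6-fold higher number from compound 1 to compound 3 (0.41 log units; beyond the scatter) and an at least 18-fold higher number from compound 2 to compound 3 (1.27 log units; beyond the scatter), while a 7.2-fold lower number from compound 1 to compound 2 (0.86 log units; beyond the scatter). Compound 4 `Nc1ncnc2c1c(Oc1cc(C(F)(F)F)ccn1)nn2[C@@H]1CC[C@H](N)C1` differs from compound 3 by 3-aminocyclopentyl in place of cyclopropyl on an aromatic nitrogen. Compound 4 brings back an amine-bearing ring resembling that of compound 1, which gave 0.917 h, so a step back down is expected for compound 4, an at least 2.4-fold lower number from compound 3 to compound 4 (0.38 log units; beyond the scatter). Compound 4 is therefore estimated at 1 h, with a range from 0.4 h to 2.4 h.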

Compound 4, half-life: 1.4 h
Compound 4: middle estimate off by 1.4-fold (0.15 log units), on the low side; the range from low to high includes it.
By their numbers in this assay, from the lowest: compound 2; then compounds 1 and 4 (each within the scatter of the next). At a limit, above all of these: compound 3.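

In this assay, moving from one amine-bearing ring to the other changes little: there is a 1.5-fold higher number from compound 1 to compound 4 (0.18 log units; within the scatter). Against the cyclobutyl, the 3-aminocyclopentyl gives an 11-fold higher number from compound 2 to compound 4 (1.04 log units; beyond the scatter), so this position tolerates the larger amine-bearing ring without the low number of compound 2. Against the cyclopropyl there is an at least 1.7-fold lower number from compound 3 to compound 4 (0.23 log units; that floor lies within the scatter), and this figure is only a floor because compound 3 stands at a limit: the limit of > 2.41 h in this assay, at which 1 of the 4 values shown sits.

The compounds shown leave open how an unsubstituted cyclopentyl would read, and how a hydroxyl in place of the amine on the ring would read. From the compounds shown here alone, the other stereoisomers of the 3-aminocyclopentyl also remain open.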